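Sulfonamide series probed for integrin alpha-1 binding

The compounds below may be only part of what the source reports. "The series", "measured", "known", "first", "only" and "open" are said of these compounds alone.

Of the compounds shown here, three have been measured in an assay on CHO cells for binding affinity to integrin alpha-1 (Homo sapiens), read by WST assay, with a stated time of 2 h; a lower number here means that less compound is needed, a higher number that more compound is needed for the effect. Compound 1, `O=C(c1ccccc1)c1cccc(NS(=O)(=O)c2ccc(Cl)cc2Cl)c1`, is the only one of them for which a number was obtained: in this assay compound 1 gives 17000 nM. Compound 2, `CN(c1cccc(C(=O)c2ccccc2)c1)S(=O)(=O)c1ccc(Cl)cc1Cl`, was reported in this assay as "not active" (no number reported), with no number attached. Compound 3, `O=C(c1ccccc1)c1ccc(OS(=O)(=O)c2ccc(Cl)cc2Cl)cc1`, likewise gave "not active" (no number reported) in this assay and no number. So compound 1 stands alone as the only quantified entry, and it is itself a weak binder; the two others that were tested did not give a measurable value at all.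

Compound 4, `O=C(c1ccccc1)c1cccc(NS(=O)(=O)c2ccc(I)cc2)c1`, has not yet been measured. It differs from compound 1 in a single place: 4-iodophenyl in place of 2,4-dichlorophenyl on a sulfonyl sulfur. Within the data shown here, no pair of measured compounds shows this kind of step, so nothing in the data tells how large it will be. Given that compound 1 at 17000 nM already sits near the weak end of what this assay reports, and that two of its three relatives returned no number, the step from compound 1 to compound 4 in this assay is expected to be modest and more likely toward a higher number than a lower one, close to the scatter, as a 1.5-fold higher number from compound 1 to compound 4 (0.17 log units; within the scatter). Compound 4 is therefore estimated at 25000 nM in this assay, with a plausible range from 8000 nM to 80000 nM, and a real chance that only a limit is reported.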

Compound 4, half-maximal effective concentration: 40000 nM
Compound 4: middle estimate off by 1.6-fold (0.20 log units), on the low side; the measured number falls inside the stated range.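

Among these compounds, the step on the sulfonyl sulfur is the first that can be sized: there is a 2.4-fold higher number from compound 1 to compound 4 (0.37 log units; beyond the scatter) in this assay, and compound 4 still returns a number, so a different aryl group at this place does not cost the reading, as happened with the changes elsewhere in compounds 2 and 3. The change itself is composite, as 2,4-dichlorophenyl takes both chlorine atoms away while 4-iodophenyl brings in a single iodine, and one step cannot separate the effect of losing the chlorines from that of gaining the iodine. No measurement at hand bears on why the number moves in this direction.

With numbers for only compound 1 and compound 4, the compounds shown leave open whether any group on the sulfonyl sulfur would bring the number down rather than up. A 4-chlorophenyl group would help to separate the two halogen changes, and a phenyl ring bearing a carboxylic acid or an amine would show whether this place tolerates something other than a halogen at all.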